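Chain length and the hydroxamate in the shared core series

This account rests on a few compounds, and the source may have more. Where it says the series, first, only, none or still open, it means among the compounds named here.

Measured so far:
compound 1 `C#CCN(C)Cc1cccc(NC(=O)CCCCCCC(=O)NO)c1` — 330 nM
compound 2 `C#CCN(C)Cc1cccc(NC(=O)CCCCCCCC(=O)NO)c1` — 4070 nM
compound 3 `C#CCN(C)Cc1ccc(NC(=O)CCCC(=O)NO)cc1` — > 10000 nM

In a functional assay on PC-3 cells (Homo sapiens) for inhibition, read by MTT assay, with a stated time of 48 h (on this read-out higher numbers stand for weaker inhibition of growth and lower numbers for stronger inhibition of growth), compound 3 gives only a limit, > 10000 nM, and no number; it sits at the limit of > 10000 nM in this assay, at which 1 of the 3 values shown sits. Compound 4 `C#CCN(C)Cc1ccc(NC(=O)CCCCCCC(=O)NO)cc1` is not yet measured. It differs from compound 3 in one place: 3-(hydroxycarbamoyl)propyl in place of hydroxycarbamoyl on a saturated chain carbon, three bonds along the chain from a carbonyl carbon.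

Within the data shown here, the only measured step that touches the same region is the chain lengthening between compound 1 and compound 2: a 12-fold higher number from compound 1 to compound 2 (1.09 log units; beyond the scatter). That step adds one chain carbon to an already long chain and weakens growth inhibition. The step from compound 3 to compound 4 is not the same move; it builds the short chain of compound 3 out to the length carried by compound 1, and compound 1 gives 330 nM in this assay. Because compound 3 sits at the limit of > 10000 nM in this assay, at which 1 of the 3 values shown sits, the step is expected to be an at least 10-fold lower number from compound 3 to compound 4 (1.00 log units; beyond the scatter), a move to a lower number that is expected to lie well beyond the scatter.

Among the measured compounds shown here, compound 4 is therefore estimated at 1000 nM, with a range from 200 nM to 6000 nM, the range being wide since no measured pair shows the change in attachment point on the shared core.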

Compound 4, concentration for 50% growth inhibition: 2280 nM
The estimate for compound 4 lay 2.3-fold (0.36 log units) below the measured number; low and high end bracket the measured number.
By their numbers in this assay, from the lowest: compound 1; then compounds 4 and 2 (each within the scatter of the next). At a limit, above all of these: compound 3.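

In this assay the change from hydroxycarbamoyl to 3-(hydroxycarbamoyl)propyl on a saturated chain carbon, three bonds along the chain from a carbonyl carbon, gives an at least 4.3-fold lower number from compound 3 to compound 4 (0.64 log units; beyond the scatter) and so shows that building out the short chain can lower the number on this attachment point of the shared core. The earlier chain step gave a 12-fold higher number from compound 1 to compound 2 (1.09 log units; beyond the scatter) on the other attachment point, so across these compounds chain lengthening does not act in one direction, with compound 2 going against the lowering seen for compound 4. The size of the new step remains open-ended, as compound 3 gives only a limit of the assay and no number: the limit of > 10000 nM in this assay, at which 1 of the 4 values shown sits.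

From the compounds shown here alone, compound 1 and compound 4 carry the same chain on different attachment points, and whether that difference alone separates compound 1 at 330 nM from compound 4 at 2280 nM stays open. Also open, going by these compounds, is how a longer chain on the attachment point of compound 4, or a carboxylic acid in place of the hydroxycarbamoyl group, would read in this assay on this core.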